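This account rests on a few compounds, and the source may have more. Where it says the series, first, only, none or still open, it means among the compounds named here.

Measured compounds:
- compound 1, `CN(C)C(=O)n1cc(C(=O)c2ccn3c2CSC3c2cccnc2)c2ccc(Sc3ccc(F)cc3)cc21` — in a functional assay (Oryctolagus cuniculus) for antagonist activity at platelet-activating factor receptor (Cavia porcellus) (on this read-out higher numbers stand for weaker inhibition and lower numbers for stronger inhibition), compound 1 gives 17 nM
- compound 2, `CC(C)(C)OC(=O)n1cc(C(=O)c2ccn3c2CSC3c2cccnc2)c2ccccc21` — compound 2 gives 110 nM
- compound 3, `NC(=O)n1cc(C(=O)c2ccn3c2CSC3c2cccnc2)c2ccc(-c3ccc(F)cc3)cc21` — compound 3 gives 6 nM

Compound 3 stands at the lowest number of the three. Compound 1 sits at a higher number, a gap beyond the usual scatter, and compound 2 sits higher still, also beyond the scatter; on these three numbers compound 3 is the strongest inhibitor.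

Compound 4, `NNC(=O)n1cc(C(=O)c2ccn3c2CSC3c2cccnc2)c2ccc(-c3ccc(F)cc3)cc21`, is built from compound 3 by one change: amino in place of hydrogen on an amide-type nitrogen, so that carbamoyl becomes aminocarbamoyl. Among the measured compounds shown here, no measured pair in this set isolates this change, so the step has to be judged without a precedent. The substituent on the indole nitrogen varies across the set while inhibition stays within a narrow band, which suggests tolerance at that position. The step from compound 3 to compound 4 is expected to be small, a 1.5-fold higher number from compound 3 to compound 4 (0.18 log units; within the scatter), with a slight loss of inhibition the more likely direction. Compound 4 is accordingly estimated at 9 nM, in the range 3 nM to 27 nM.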

Compound 4, inhibition constant: 25 nM
The estimate for compound 4 lay 2.8-fold (0.44 log units) below the measured number; the measured number falls inside the stated range.
By their numbers in this assay, from the lowest: compound 3; then compounds 1 and 4 (each within the scatter of the next); then compound 2.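

In this assay, among the compounds shown here, amino in place of hydrogen on an amide-type nitrogen gives a 4.2-fold higher number from compound 3 to compound 4 (0.62 log units; beyond the scatter), the first step here that isolates a single change at this place. It shows that carbamoyl cannot be extended to aminocarbamoyl without a loss of inhibition beyond the scatter, although compound 4 still gives 25 nM. Nothing at hand gives a reason for this loss.

The compounds shown leave open whether a methyl, a hydroxyl or a longer chain such as aminoethyl on that same nitrogen would cost as much as amino does. They also leave open how dimethylcarbamoyl or tert-butoxycarbonyl would compare with carbamoyl on their own, since compound 1 and compound 2 differ from compound 3 in more than one place.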